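Swapping a urea end group for an oxetane ring

The compounds below may be only part of what the source reports. "The series", "measured", "known", "first", "only" and "open" are said of these compounds alone.

Two closely related compounds have been tested for how much survives a short exposure to liver enzymes. Compound 1 `NCCCCN(C[C@@H]1Cc2cccnc2CN1)[C@H]1CCCc2cccnc21` carries a free primary amine at the end of a four-carbon chain. In an ADME assay on microsomes from liver (Homo sapiens) for metabolic stability, using NADPH, with a stated time of 10 min (a lower number here means that less of the compound is left, a higher number that more of the compound is left), compound 1 gives 92%. Compound 2 `NC(=O)NCCCCN(C[C@H]1Cc2ncccc2CN1)[C@H]1CCCc2cccnc21` caps that chain end with a urea and is otherwise built on the same core. In this assay compound 2 gives 91%, the lower of the two numbers, although the gap to compound 1 is within the scatter, so the two are best read as equivalent.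

Compound 3 `c1cnc2c(c1)CN[C@@H](CN(CCCCNC1COC1)[C@H]1CCCc3cccnc31)C2` differs from compound 2 in one place: oxetan-3-yl in place of carbamoyl on an amine nitrogen. For the measured compounds named here, no pair of measured compounds shows the effect of this particular exchange, so there is no measured step to lean on. Since compound 2 and compound 1 both sit near the top of the scale in this assay, a large change in either direction is not expected, and the step of a number 6 percentage points lower from compound 2 to compound 3 (within the scatter) is estimated to stay within the scatter. Compound 3 is therefore expected to give about 85%, with a plausible range from 68% to 96%.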

Compound 3, percent of the compound remaining: 97%
The estimate for compound 3 lay 12 percentage points below the measured number; measured number outside the range, above it.
By their numbers in this assay, from the lowest: compounds 2, 1 and 3 (each within the scatter of the next).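

In this assay, oxetan-3-yl in place of carbamoyl on an amine nitrogen gives a number 6 percentage points higher from compound 2 to compound 3 (within the scatter), so the two end groups cannot be told apart here. For the compounds shown here, this is the first measured exchange at this chain end, and it is not a small one on paper: carbamoyl brings a double bond outside aromatic rings and a hydrogen-bond donor, while oxetan-3-yl has neither and brings a four-membered non-aromatic ring instead. Even so, the read-out remains near the top of the scale, which suggests that, for this pair, this position tolerates a marked change of end group in this test, though no measurement at hand explains the outcome.

On these data alone, what remains open is whether the same holds for other groups on this nitrogen, such as an acetyl group, a methylsulfonyl group or a cyclobutyl ring, or for a longer chain in place of the four-carbon one. As far as these compounds go, because these numbers all sit so close to the top of the scale, it is also open whether the two end groups would still look alike under a harder test of stability.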